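Removing one methoxy from the aryl ketone of compound 3

The source may hold more compounds than are shown below. What is called first, only, known or untested is meant among the compounds shown, and "the series" means these compounds.

For the measured compounds named here, compound 3, `COc1ccc(C(=O)/C=C/c2cc(-c3cc(OC)c(OC)c(OC)c3)n[nH]2)cc1OC`, is the only compound of the set with a number in a functional assay on IGROV-1 cells (Homo sapiens) for inhibition, read by sulforhodamine B assay, with a stated time of 48 h; a higher number here means that more compound is tolerated, a lower number that less compound is tolerated: in that assay compound 3 gives 6480 nM. Compound 1, `COc1cc(-c2cc(/C=C/C(=O)c3ccc(N)cc3)[nH]n2)cc(OC)c1OC`, gives only a limit of the assay in this assay, > 100000 nM. Compound 2, `COc1cc(-c2cc(/C=C/C(=O)c3ccc(Cl)c(Cl)c3)[nH]n2)cc(OC)c1OC`, likewise gives only a limit of the assay, > 100000 nM. Both limits sit at the limit of > 100000 nM in this assay, at which 2 of the 3 values shown sit. The two steps that lead to compound 3 are large: an at least 15-fold lower number from compound 1 to compound 3 (1.18 log units; beyond the scatter) and an at least 15-fold lower number from compound 2 to compound 3 (1.18 log units; beyond the scatter), while a step that the two limits leave unreadable from compound 1 to compound 2.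

Compound 4, `COc1ccc(C(=O)/C=C/c2cc(-c3cc(OC)c(OC)c(OC)c3)n[nH]2)cc1`, differs from compound 3 by hydrogen in place of methoxy on an aromatic carbon. Going by the values given here, no measured step removes a methoxy from this ring, so the step can only be read indirectly; what the measured steps do show is that this ring on the carbonyl carbon decides whether a number is reached at all. A modest loss is therefore the expectation, and compound 4 is estimated at 15000 nM, within 5000 nM to 50000 nM, meaning an expected step of a 2.3-fold higher number from compound 3 to compound 4 (0.36 log units; beyond the scatter).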

Compound 4, concentration lethal to 50% of the cells: > 100000 nM
Compound 4: only a limit was reported (the forecaster's own chance of this, stated with the estimate: 25%); at least 6.6-fold (0.82 log units) between middle value and limit.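

In this assay, for the compounds shown here, removing a single methoxy is enough to lose the only number in the set: an at least 15-fold higher number from compound 3 to compound 4 (1.18 log units; beyond the scatter). The earlier steps shown here exchanged substituents across the ring on the carbonyl carbon, whereas this one shows that hydrogen in place of methoxy at this one position, turning 3,4-dimethoxyphenyl into 4-methoxyphenyl, carries a large step on its own. The value of compound 4 is a limit of the assay, so the steps that link compound 4 with compound 1 and compound 2 cannot be read, and it joins them at the same limit: the limit of > 100000 nM in this assay, at which 3 of the 4 values shown sit.

The limit leaves open how far the true value of compound 4 lies from that of compound 3. From the compounds shown here alone, it also remains open whether only a methoxy serves at this position, or whether a hydroxyl, a fluorine or an ethoxy would keep a readable number.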